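This account rests on a few compounds, and the source may have more. Where it says the series, first, only, none or still open, it means among the compounds named here.

Compound 1 `CC1(C)[C@H]2CC[C@]1(C)N(Cc1cn(-c3ccccc3C#N)nn1)C(=O)C2`: 110 nM
Compound 2 `CC1(C)[C@H]2CC[C@]1(C)N(Cc1cn(-c3ccc(O)cc3)nn1)C(=O)C2`: 410 nM
Compound 3 `CC1(C)[C@H]2CC[C@]1(C)N(Cc1cn(-c3cccc(Br)c3)nn1)C(=O)C2`: 30 nM

In a functional assay on OVCAR-3 cells (Homo sapiens) for inhibition, read by MTT assay, with a stated time of 24 h (on this read-out higher numbers stand for weaker inhibition and lower numbers for stronger inhibition), compound 3 gives 30 nM, the lowest of the three numbers. Compound 4 `COc1ccc(-n2cc(CN3C(=O)C[C@@H]4CC[C@@]3(C)C4(C)C)nn2)cc1` has not yet been measured. It carries 4-methoxyphenyl in place of 3-bromophenyl on an aromatic nitrogen.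

Within the data shown here, no measured compound carries 4-methoxyphenyl, so the expectation rests on the two steps that lead to compound 3. The large one is a 14-fold lower number from compound 2 to compound 3 (1.14 log units; beyond the scatter), which starts from the 4-hydroxyphenyl compound. The modest one is a 3.7-fold lower number from compound 1 to compound 3 (0.56 log units; beyond the scatter), which starts from the 2-cyanophenyl compound. Each of the other two aryl groups measured so far therefore gives a higher number than 3-bromophenyl.

On that basis, a step of modest to large size towards a higher number is expected in this assay, and the expected change is a 5.7-fold higher number from compound 3 to compound 4 (0.75 log units; beyond the scatter). Compound 4 is estimated at 170 nM, with an expected range from 60 nM to 480 nM.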

Compound 4, half-maximal inhibitory concentration: 250 nM
Estimate against measurement, compound 4: 1.5-fold (0.17 log units) below; measured number inside the range.
By their numbers in this assay, from the lowest: compound 3; then compound 1; then compounds 4 and 2 (each within the scatter of the next).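

In this assay, masking the hydroxyl of compound 2 as its methyl ether leaves the result within the scatter, a 1.6-fold lower number from compound 2 to compound 4 (0.21 log units; within the scatter), so at this position the two groups with oxygen on the phenyl ring read alike. Both stand well apart from 3-bromophenyl, with an 8.3-fold higher number from compound 3 to compound 4 (0.92 log units; beyond the scatter), and 4-methoxyphenyl also falls short of 2-cyanophenyl, with a 2.3-fold higher number from compound 1 to compound 4 (0.36 log units; beyond the scatter), which leaves compound 3 with the lowest number of the four and compound 1 second. No measurement offered here explains these differences.

The compounds shown do not separate the exchange of bromine for methoxy from the change in ring position, a question that 3-methoxyphenyl and 4-bromophenyl would address. Going by these compounds, how 4-aminophenyl or a 3-chlorophenyl group would read on this nitrogen also remains open.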